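Swapping the oxiran-2-yl group of compound 3

This account rests on a few compounds, and the source may have more. Where it says the series, first, only, none or still open, it means among the compounds named here.

Values in a functional assay on MDA-MB-468 cells (Homo sapiens) for inhibition, read by CCK-8 assay and cell counting, with a stated time of 2 days (on this read-out higher numbers stand for weaker inhibition and lower numbers for stronger inhibition), for the compounds measured so far:
- compound 1 `O=C(/C=C/c1ccco1)c1ccc(OCC2CO2)cc1` gives 48900 nM
- compound 2 `O=C(/C=C/c1ccc(OCC2CO2)cc1)c1ccco1` gives 17300 nM
- compound 3 `O=C(/C=C/c1ccc(OCC2CO2)cc1)c1cccs1` gives 6300 nM

Compound 3 has the lowest number of the three, which makes it the strongest inhibitor so far. The next structure is compound 4 `O=C(/C=C/c1ccc(OCC(O)CCl)cc1)c1cccs1` (change: 2-chloro-1-hydroxyethyl in place of oxiran-2-yl on a saturated chain carbon bound to an oxygen on an aromatic ring). In words, 2-chloro-1-hydroxyethyl takes the place of oxiran-2-yl on a saturated chain carbon bound to an oxygen on an aromatic ring.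

For the measured compounds named here, no measured step touches this group, since all three measured compounds carry oxiran-2-yl. Going by the values given here, the only single-place step is a 2.7-fold lower number from compound 2 to compound 3 (0.44 log units; beyond the scatter) and it concerns thiophen-2-yl and furan-2-yl, so it offers a sense of scale but no direction. With compound 3 already lowest, a modest step of similar size toward a higher number seems the likeliest outcome in this assay for this new change. That expectation amounts to an estimated 2.2-fold higher number from compound 3 to compound 4 (0.35 log units; beyond the scatter) as the working guess. Compound 4 is expected to read about 14000 nM with an estimated range from 4500 nM to 42000 nM as its likely span.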

Compound 4, half-maximal inhibitory concentration: 7750 nM
Compound 4: middle estimate off by 1.8-fold (0.26 log units), on the high side; measured number inside the range.
By their numbers in this assay, from the lowest: compounds 3 and 4 (each within the scatter of the next); then compound 2; then compound 1.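

In this assay, putting 2-chloro-1-hydroxyethyl in place of oxiran-2-yl gives a 1.2-fold higher number from compound 3 to compound 4 (0.09 log units; within the scatter), the first step shown that touches this position. The three-membered ring can therefore go without a change that this assay can separate from the scatter, even though the group that enters has no ring and brings a hydrogen-bond donor. The data shown offer no measurement that explains why the two groups cannot be told apart.

Going by these compounds, it remains open whether other groups at this place, such as an amine or a longer chain ending in a carboxylic acid, would also leave the number unchanged or would shift it. On these data alone, it is also open whether the same swap would behave alike on compound 2, which carries furan-2-yl instead of thiophen-2-yl.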